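Methyl Walks the Ring: Compound 1 to Compound 4

The source may report more compounds than this note shows. Statements on the series, on what has been measured and on what is new or still open speak of the compounds shown alone.

Measured so far:
Compound 1, `Cc1ccccc1CCC(=O)N[C@@H](C(=O)N1CCC(c2ccc(Cl)cc2)CC1)C(C)C`, 19 nM
Compound 2, `CC[C@@H](C)[C@@H](NC(=O)c1ccccc1)C(=O)N1CCC(c2ccc(Cl)cc2)CC1`, 45 nM
Compound 3, `CC[C@@H](C)[C@@H](NC(=O)CCc1ccccc1)C(=O)N1CCC(c2ccc(Cl)cc2)CC1`, 66 nM

Of the compounds shown here, three sharing one core have been measured in an assay on THP-1 cells for displacement of a labelled ligand from C-C chemokine receptor type 1 (Homo sapiens); on this read-out lower numbers stand for stronger inhibition and higher numbers for weaker inhibition. Compound 1 gives the lowest number of the three, at 19 nM, while compound 2 gives 45 nM and compound 3 gives 66 nM. Among the compounds with values here, the only single-point step among them, a 1.5-fold higher number from compound 2 to compound 3 (0.17 log units; within the scatter), shows that stretching the acyl group from phenyl to phenethyl leaves the number essentially where it was.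

Compound 4, `Cc1cccc(CCC(=O)N[C@@H](C(=O)N2CCC(c3ccc(Cl)cc3)CC2)C(C)C)c1`, has not yet been measured. It differs from compound 1 by 3-methylphenyl in place of 2-methylphenyl on a saturated chain carbon, two bonds along the chain from a carbonyl carbon. Within the data shown here, none of the measured steps alters the methyl on the aromatic ring; the one step on record touches the acyl chain length and stays within the scatter. Nothing in the data therefore points to a large movement in either direction, and the expectation is a change no larger than the scatter. Compound 4 is estimated at 25 nM, within 10 nM to 60 nM. The expected step is a 1.3-fold higher number from compound 1 to compound 4 (0.12 log units; within the scatter).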

Compound 4, half-maximal inhibitory concentration: 22 nM
Compound 4: the middle estimate sits 1.1-fold (0.06 log units) above what was measured; low and high end bracket the measured number.
By their numbers in this assay, from the lowest: compounds 1 and 4 (each within the scatter of the next); then compounds 2 and 3 (each within the scatter of the next).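

In this assay, the change from 2-methylphenyl to 3-methylphenyl, on a saturated chain carbon, two bonds along the chain from a carbonyl carbon, gives a 1.2-fold higher number from compound 1 to compound 4 (0.06 log units; within the scatter). The earlier compounds shown here offered only a step in the length of the acyl chain, whereas this pair tests the aromatic ring itself and shows that, with the same atoms joined differently, these two placements of the methyl cannot be told apart on this read-out. There is no supporting measurement that could explain why the two compounds read alike.

Going by these compounds, it remains open whether the methyl contributes at all, and whether plain phenyl, or a ring carrying chlorine, methoxy or an amine in its place, would keep the number in the same range. Within the data shown here, also open is whether a longer chain between the ring and the carbonyl would be tolerated with the core of compound 1, since the only step in chain length on record, a 1.5-fold higher number from compound 2 to compound 3 (0.17 log units; within the scatter), was read on a different core and starts from a phenyl directly on the carbonyl carbon.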